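Swapping Chlorine for Fluorine on a Plasma Stability Series

A few compounds are considered here, and "the series" means these few. Any claim that something is new, unique, unknown or untested is made for them only; others in the source may bear on it.

Three compounds sharing one core were examined in an ADME assay on a cell-free system (plasma, Rattus norvegicus) for metabolic stability, read by LC-MS, with a stated time of 60 min, tested at 100 uM; on this read-out higher numbers stand for a more stable compound and lower numbers for a less stable compound. Compound 1, `Cc1c(OCCCCOc2ccc(C(=O)O)cc2Cl)ccc(C(=O)CC2CCCC2)c1O`, gives 120%, the highest of the three readings. Compound 2, `Cc1c(OCCCCOc2ccc(C(=O)O)cc2)ccc(C(=O)CC(C)C)c1O`, gives 95% in this assay, and compound 3, `CCCC(=O)c1ccc(OCCCCOc2cc(C(=O)O)ccc2OC)c(C)c1O`, gives 78%. Both of these fall below compound 1 by more than the scatter. The not yet measured compound 4, `Cc1c(OCCCCOc2ccc(C(=O)O)cc2F)ccc(C(=O)CC2CCCC2)c1O`, differs from compound 1 by a single exchange: fluoro in place of chloro on an aromatic carbon. The chloro leaves and a fluoro enters on an aromatic carbon. Among the measured compounds shown here, no measured pair of compounds shows this exchange, so its effect is not known from the data. The step of a number 10 percentage points lower from compound 1 to compound 4 (within the scatter) in this assay is expected to be small, within the scatter. Compound 4 is estimated at 110%, with a range from 88% to 130%.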

Compound 4, percent of the compound remaining: 97%
For compound 4 the middle estimate is 13 percentage points above the measured one, and the stated range covers the measured number.
By their numbers in this assay, from the lowest: compound 3; then compounds 2 and 4 (each within the scatter of the next); then compound 1.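

In this assay, the place ortho to a large group and meta to a carboxy group proves sensitive to the atom it carries: fluoro in place of chloro gives a number 23 percentage points lower from compound 1 to compound 4 (beyond the scatter). Among the compounds shown here, this is the first pair that differs in one place, so the change can be read on its own. Nothing in the available data explains the step.

The compounds shown leave open how a bromo or a methyl group at this place would read on the core of compound 1. They also leave open whether the same exchange would give a similar step with a different chain on the carbonyl.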